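The source may report more compounds than this note shows. Statements on the series, on what has been measured and on what is new or still open speak of the compounds shown alone.

Three compounds measured in a functional assay on HCT-116 cells (Homo sapiens) for antiproliferative activity; on this read-out lower numbers stand for stronger inhibition and higher numbers for weaker inhibition:

- compound 1 `CCCCO/N=C/c1c(N)ncnc1Oc1ccc2[nH]c(C)cc2c1F`: 1000 nM
- compound 2 `Cc1cc2c(F)c(Oc3ncnc(N)c3/C=N/OCCO)ccc2[nH]1`: 323 nM
- compound 3 `Cc1cc2c(F)c(Oc3ncnc(N)c3/C=N/OCc3ccccc3)ccc2[nH]1`: 311 nM

Compound 3 stands level with compound 2 and clear of compound 1. The next compound is compound 4 `COCCO/N=C/c1c(N)ncnc1Oc1ccc2[nH]c(C)cc2c1F`, and the change is methoxymethyl in place of phenyl on a saturated chain carbon bound to an oxygen: methoxymethyl in place of phenyl, or benzyl to 2-methoxyethyl. The closest evidence is a 1.0-fold lower number from compound 2 to compound 3 (0.02 log units; within the scatter), where a different swap at this place left the number unmoved. The two modest steps, a 3.1-fold lower number from compound 1 to compound 2 (0.49 log units; beyond the scatter) and a 3.2-fold lower number from compound 1 to compound 3 (0.51 log units; beyond the scatter), set compound 1 apart, so some upward drift is possible. No step beyond the scatter is expected, and the expected step is a 1.3-fold higher number from compound 3 to compound 4 (0.11 log units; within the scatter). Compound 4 is estimated at 400 nM, with an expected range of 190 nM to 850 nM.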

Compound 4, half-maximal inhibitory concentration: 387 nM
Compound 4: the middle estimate sits 1.0-fold (0.01 log units) above what was measured, within the range that was stated.
By their numbers in this assay, from the lowest: compounds 3, 2 and 4 (each within the scatter of the next); then compound 1.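

Methoxymethyl in place of phenyl (a 1.2-fold higher number from compound 3 to compound 4 (0.09 log units; within the scatter)) stays within the scatter, so at this saturated chain carbon bound to an oxygen, a group with no ring reads level with one carrying an aromatic ring. Methyl in place of hydrogen on the chain's end oxygen (a 1.2-fold higher number from compound 2 to compound 4 (0.08 log units; within the scatter)) also stays within the scatter, while compound 1 remains apart (a 2.6-fold lower number from compound 1 to compound 4 (0.41 log units; beyond the scatter)). Nothing available explains these results. On these data alone, whether an amine, a carboxylic acid or a longer chain ending in methoxy would stay level with compound 2, compound 3 and compound 4 remains open.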